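Trihydroxyphenyl replacement in a sulfonyl enone series

This account rests on a few compounds, and the source may have more. Where it says the series, first, only, none or still open, it means among the compounds named here.

Measured so far:
compound 1 `Cc1ccc(CS(=O)(=O)/C(=C/c2c[nH]c3ccccc23)C(=O)c2ccc(Cl)cc2)cc1` gives 25000 nM
compound 2 `CSc1ccc(/C=C(\C(=O)c2ccc(Cl)cc2)S(=O)(=O)Cc2ccc(C)cc2)cc1` gives 10000 nM
compound 3 `CCOc1ccc(/C=C(\C(=O)c2ccc(Cl)cc2)S(=O)(=O)Cc2ccc(C)cc2)cc1OC` gives 10000 nM

All values come from a functional assay on DU-145 cells (Homo sapiens) for inhibition, read by trypan blue exclusion, with a stated time of 96 h; on this read-out higher numbers stand for weaker inhibition of growth and lower numbers for stronger inhibition of growth. For the measured compounds named here, compound 3 stands level with compound 2 at the digits printed, and together they hold the lowest numbers of the three; its only step beyond the scatter is a 2.5-fold lower number from compound 1 to compound 3 (0.40 log units; beyond the scatter), mirrored by a 2.5-fold lower number from compound 1 to compound 2 (0.40 log units; beyond the scatter). The swap of one aryl group for another within compound 2 and compound 3 gives no change at the digits printed from compound 2 to compound 3 (within the scatter).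

Compound 4 `Cc1ccc(CS(=O)(=O)/C(=C/c2c(O)cc(O)cc2O)C(=O)c2ccc(Cl)cc2)cc1` has not yet been measured. It differs from compound 3 as follows: 2,4,6-trihydroxyphenyl in place of 4-ethoxy-3-methoxyphenyl on a double-bonded chain carbon bound to a double-bonded chain carbon. Going by the values given here, no measured step involves a 2,4,6-trihydroxyphenyl group, so nothing bears directly on this change. Among the compounds with values here, the one aryl-for-aryl swap on record, no change at the digits printed from compound 2 to compound 3 (within the scatter), lay within the scatter, while a 2.5-fold lower number from compound 1 to compound 3 (0.40 log units; beyond the scatter) shows that a different ring type at this position can move the number modestly. Compound 4 is therefore expected to remain close to compound 3, with a step of no change at the digits printed from compound 3 to compound 4 (within the scatter) in this assay. The estimate for compound 4 is 10000 nM, with a range from 3000 nM to 30000 nM.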

Compound 4, concentration for 50% growth inhibition: > 100000 nM
Compound 4 ended at the assay's limit (the forecaster's own chance of this, stated with the estimate: 10%); middle value at least 10-fold (1.00 log units) from the limit.
By their numbers in this assay, from the lowest: compounds 2 and 3 (each within the scatter of the next); then compound 1. At a limit, above all of these: compound 4.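

Compound 4 ends at a limit of this assay, not at a number: the limit of > 100000 nM in this assay, at which 1 of the 4 values shown sits.

This position is therefore not indifferent to the aryl group, as the within-scatter swap between compound 2 and compound 3 might have suggested: 2,4,6-trihydroxyphenyl gives an at least 10-fold higher number from compound 3 to compound 4 (1.00 log units; beyond the scatter) and an at least 10-fold higher number from compound 2 to compound 4 (1.00 log units; beyond the scatter). Going by these compounds, the same group also compares poorly with the 1H-indol-3-yl group, with an at least 4.0-fold higher number from compound 1 to compound 4 (0.60 log units; beyond the scatter), and, since these steps rest on a limit, their full size stays unknown.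

The change from 4-ethoxy-3-methoxyphenyl swaps 0 hydrogen-bond donors for 3, but the compounds shown do not tell whether the free hydroxyl groups or the arrangement of the three oxygens on the ring drives the result. A 2,4,6-trimethoxyphenyl group and a 4-hydroxyphenyl group at this position would help separate these two readings.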